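The source may hold more compounds than are shown below. What is called first, only, known or untested is meant among the compounds shown, and "the series" means these compounds.

Measured so far in a functional assay on SW480 cells (Homo sapiens) for cytotoxicity, read by MTT assay, with a stated time of 4 days; on this read-out higher numbers stand for weaker inhibition and lower numbers for stronger inhibition:
Compound 1 `C=C1C[C@]23C[C@@]1(O)CC[C@H]2c1ccc(O)c(C)c1[C@@H]3Cn1cc(-c2ccccn2)nn1` gives > 20000 nM, a limit of the assay rather than a number.
Compound 2 `C=C1C[C@]23C[C@@]1(O)CC[C@H]2c1ccc(O)c(C)c1[C@@H]3Cn1cc(-c2ccc(Br)cc2)nn1` gives > 20000 nM, likewise a limit of the assay.

Compound 2 therefore stands at the limit of > 20000 nM in this assay, at which 2 of the 2 values shown sit, with no number to place it within this assay. Going by the values given here, the single measured step, a step that the two limits leave unreadable from compound 1 to compound 2, cannot be read from the two limits. Compound 3 `C=C1C[C@]23C[C@@]1(O)CC[C@H]2c1ccc(O)c(C)c1[C@@H]3Cn1cc(-c2ccccc2)nn1` differs from compound 2 by hydrogen in place of bromo on an aromatic carbon. No readable step bears on this change, so no direction and no size beyond the scatter can be drawn from it. Compound 3 is expected to stay at the limit too, an estimated 30000 nM with range 15000 nM to 80000 nM. That amounts to an estimated step that the limit leaves unreadable from compound 2 to compound 3, expected to lie within the scatter.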

Compound 3, half-maximal inhibitory concentration: > 20000 nM
Compound 3 was reported as a limit; the forecaster's own chance of this, stated with the estimate: 85%; the middle value does not contradict the limit.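

No new step can be read among compound 1, compound 2 and compound 3, since all three values are limits of the assay rather than numbers. Still open, from the compounds shown here alone, is whether pyridin-2-yl, phenyl and 4-bromophenyl differ at all in this assay.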